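Amidrazone in place of amidoxime on the nucleoside core

The compounds below may be only part of what the source reports. "The series", "measured", "known", "first", "only" and "open" are said of these compounds alone.

Two compounds of this series carry numbers in a functional assay on KB cells (Homo sapiens) for inhibition; on this read-out higher numbers stand for weaker inhibition and lower numbers for stronger inhibition. Going by the values given here, compound 1 `N/C(=N\O)c1cn([C@@H]2O[C@H](CO)[C@@H](O)[C@H]2O)c2nnnc(N)c12` is the more active of the pair; in this assay compound 1 gives 1500 nM, the lowest number measured so far. Among the compounds with values here, the only other measured compound, compound 2 `Cc1ccc(C(=O)OC[C@H]2O[C@@H](n3cc(C(N)=O)c(C(N)=O)c3N)C[C@@H]2OC(=O)c2ccc(C)cc2)cc1`, differs from compound 1 in many places at once, and in this assay compound 2 gives 100000 nM, a gap beyond the scatter. Within the data shown here, no pair of measured compounds differs in one place only, so no step size has been observed directly.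

Compound 3 `N=C(NN)c1cn([C@@H]2O[C@H](CO)[C@@H](O)[C@H]2O)c2nnnc(N)c12` keeps the core of compound 1 and changes only the side group, (a group of 4 heavy atoms (1 carbon, 3 nitrogen; no ring) in place of a group of 4 heavy atoms (1 carbon, 2 nitrogen, 1 oxygen; no ring), on an aromatic carbon). The group that enters has one more hydrogen-bond donor than the one that leaves; the rest of the molecule is untouched.

Among the measured compounds shown here, with no measured single-point step to lean on, the expectation is a small change, if any: the step of a 1.7-fold higher number from compound 1 to compound 3 (0.22 log units; within the scatter) is estimated to stay close to the scatter, with a slight lean toward weaker inhibition. Compound 3 is thus expected to give about 2500 nM in this assay, within a range of 600 nM to 10000 nM.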

Compound 3, half-maximal inhibitory concentration: 3000 nM
Compound 3: middle estimate off by 1.2-fold (0.08 log units), on the low side, and the stated range covers the measured number.
By their numbers in this assay, from the lowest: compounds 1 and 3 (each within the scatter of the next); then compound 2.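

In this assay, going by these compounds alone, the exchange of the side group on an aromatic carbon gives the first single-place step: a 2.0-fold higher number from compound 1 to compound 3 (0.30 log units; within the scatter). At this position, the group that enters, with its three nitrogens, and the group that leaves, with its two nitrogens and one oxygen, thus give numbers within the scatter of each other, despite their difference in hydrogen-bond donors, and the activity seen with the core of compound 1 does not depend on that oxygen being present in this side group. Nothing on hand explains this result or gives any measured property of the two groups.

The compounds shown test only two closely matched side groups of equal heavy-atom count, so it remains open whether a nitrile, a carboxylic acid or a longer chain on the same aromatic carbon would also stay within the scatter of compound 1. As far as these compounds go, it also remains open whether this exchange would give a similar step on a different core or in a different assay.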